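Swapping an aryl ether for an isopentyl chain

The source may hold more compounds than are shown below. What is called first, only, known or untested is meant among the compounds shown, and "the series" means these compounds.

Three compounds have been measured in a physicochemical assay for acid dissociation:

Compound 1, `COc1ccc(Oc2ccc3c(NCCCNCc4cc(F)ccc4OC)ccnc3c2)cc1`, gives 9.28.
Compound 2, `c1ccc(-c2ccc3c(NCCCNCc4ccco4)ccnc3c2)cc1`, gives 9.47.
Compound 3, `COc1ccc(Oc2ccc3c(NCCCNCc4cccc(OC)c4O)ccnc3c2)cc1`, gives 9.28.

Compound 3 sits level with compound 1, and the number for compound 2 is within the usual scatter of both. The one step that joins two of these compounds, no change at the digits printed from compound 1 to compound 3 (within the scatter), changes the aryl group on the chain carbon bound to an amine nitrogen and leaves the reading untouched.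

Compound 4, `COc1cccc(CNCCCNc2ccnc3cc(CCC(C)C)ccc23)c1O`, is the next compound to be measured. It differs from compound 3 as follows:

isopentyl in place of 4-methoxyphenoxy on an aromatic carbon

Going by the values given here, no measured step touches this aromatic carbon of the shared core; the only step known alters a group far from it and shows no change. The change from compound 3 to compound 4 therefore has no direct precedent among these compounds, and the working expectation is that a number 0.02 log units higher from compound 3 to compound 4 (within the scatter) stays within the scatter. On that basis compound 4 is estimated at 9.3, with a range from 8.9 to 9.7 in this assay.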

Compound 4, acid dissociation constant: 9.47
For compound 4 the middle estimate is 0.17 log units below the measured one; low and high end bracket the measured number.
By their numbers in this assay, from the lowest: compounds 1, 3, 2 and 4 (each within the scatter of the next).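

In this assay, going by these compounds alone, the swap of 4-methoxyphenoxy for isopentyl on this aromatic carbon gives a number 0.19 log units higher from compound 3 to compound 4 (within the scatter) and provides the first measured step at this position of the shared core. The two groups differ considerably: one has 9 heavy atoms, a six-membered aromatic ring of carbon only and 2 hydrogen-bond acceptors, while the other has 5 heavy atoms, all carbon, with no ring and no hydrogen-bond acceptors, yet for this pair the difference in the reading stays within the scatter. No independent measurement is available to explain this result.

This single pair cannot show whether the reading would also stay within the scatter with a different kind of group on this aromatic carbon, such as an amine, a carboxylic acid or a longer carbon chain. From the compounds shown here alone, it also remains open whether swapping the aryl group on the chain carbon bound to an amine nitrogen would leave the reading just as unchanged with isopentyl on the core.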